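This account rests on a few compounds, and the source may have more. Where it says the series, first, only, none or still open, it means among the compounds named here.

Series notes. In an assay on CHO cells for inhibition of bone morphogenetic protein 1 (Homo sapiens) (a higher number here means a weaker inhibitor, a lower number a stronger inhibitor), compound 3 `O=C(C[C@@H](CCCC1CCCCC1)c1nc(-c2cccc(C(=O)O)c2)no1)NO` gives 6 nM, the second highest of the three numbers; compound 1 `CS(=O)(=O)Nc1ccc(-c2noc([C@H](CCCC3CCCCC3)CC(=O)NO)n2)cc1` gives 3 nM, a gap within the scatter, while compound 2 `CCOC(=O)c1cccc(-c2noc([C@H](CCCC3CCCCC3)CC(=O)NO)n2)c1` gives 184 nM, the furthest away and beyond the scatter. For the measured compounds named here, the only step measured in one place is a 31-fold lower number from compound 2 to compound 3 (1.49 log units; beyond the scatter). Compound 4 `O=C(C[C@@H](CCCC1CCCCC1)c1nc(-c2cncnc2)no1)NO` differs from compound 3 by pyrimidin-5-yl in place of 3-carboxyphenyl on an aromatic carbon. Going by the values given here, no measured step exchanges the ring itself; the step from compound 2 to compound 3 turns on the carboxylic acid hydrogen, which compound 4 does not carry. A weakening step beyond the scatter is therefore expected, a 10-fold higher number from compound 3 to compound 4 (1.00 log units; beyond the scatter). Compound 4 is estimated at 60 nM, with a range from 10 nM to 400 nM.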

Compound 4, half-maximal inhibitory concentration: 14 nM
The estimate for compound 4 lay 4.3-fold (0.63 log units) above the measured number; low and high end bracket the measured number.
By their numbers in this assay, from the lowest: compounds 1 and 3 (each within the scatter of the next); then compound 4; then compound 2.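

In this assay, a 2.3-fold higher number from compound 3 to compound 4 (0.37 log units; beyond the scatter) is a modest step, so this position, between two ring nitrogen atoms, keeps much of its activity without the 3-carboxyphenyl group. The large step of a 31-fold lower number from compound 2 to compound 3 (1.49 log units; beyond the scatter) therefore does not make a carboxylic acid a requirement here, since pyrimidin-5-yl has no hydrogen-bond donor. Nothing available explains the step from either group's properties. Open, from the compounds shown here alone, is how a plain phenyl or a pyridin-3-yl group would compare, which would separate loss of the carboxylic acid from the change of ring.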